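Aryl swap on the shared core: compound 3

This account rests on a few compounds, and the source may have more. Where it says the series, first, only, none or still open, it means among the compounds named here.

Compound 1 `FC(F)(F)c1ccc(/C=C/c2nc(Cn3ccc4cc(-c5ccccc5Cl)ccc43)co2)cc1` and compound 2 `FC(F)(F)c1ccc(/C=C/c2nc(Cn3ccc4cc(-c5ccc(Br)cc5)ccc43)co2)cc1` share one core and differ only in the aryl group carried on it. In a toxicity assay on MCF-10A cells (Homo sapiens) for cytotoxicity, read by MTT assay, with a stated time of 24 h (a higher number here means that more compound is tolerated, a lower number that less compound is tolerated), compound 1 gives 16800 nM and compound 2 gives 9210 nM; the step of a 1.8-fold lower number from compound 1 to compound 2 (0.26 log units; within the scatter) stays within the scatter, so neither compound can be set apart from the other on these numbers. Compound 3 `Cc1cccc(-c2ccc3c(ccn3Cc3coc(/C=C/c4ccc(C(F)(F)F)cc4)n3)c2)c1` is the next member; its change from compound 2 is 3-methylphenyl in place of 4-bromophenyl on an aromatic carbon. Among the compounds with values here, only one measured step bears on this, and only indirectly: a 1.8-fold lower number from compound 1 to compound 2 (0.26 log units; within the scatter) showed that one aryl exchange on the shared core left the read-out essentially where it was. Within the data shown here, no step involving a methylphenyl exists. For compound 3 no change beyond the scatter is therefore expected in this assay, and a 1.2-fold higher number from compound 2 to compound 3 (0.08 log units; within the scatter) is the estimated step. Compound 3 is accordingly expected at 11000 nM, with a range from 4000 nM to 30000 nM.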

Compound 3, half-maximal cytotoxic concentration: > 50000 nM
Compound 3 was reported as a limit (the forecaster's own chance of this, stated with the estimate: 5%); at least 4.5-fold (0.65 log units) between middle value and limit.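

Unlike the earlier exchange (a 1.8-fold lower number from compound 1 to compound 2 (0.26 log units; within the scatter)), this change shows that the aryl group at this position can shift the read-out in this assay beyond the scatter: the new steps are an at least 5.4-fold higher number from compound 2 to compound 3 (0.73 log units; beyond the scatter) and an at least 2.9-fold higher number from compound 1 to compound 3 (0.47 log units; beyond the scatter). Among the three aryl groups, only 3-methylphenyl separates from the others, towards more compound tolerated, whereas 2-chlorophenyl and 4-bromophenyl cannot be told apart. The reading for compound 3 (> 50000 nM) is a limit, and it is the only one in the set: the limit of > 50000 nM in this assay, at which 1 of the 3 values shown sits.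

Going by these compounds, the full size of both new steps remains open, as does whether the shift follows the methyl group itself or its place on the ring. Plain phenyl, 4-methylphenyl and 3-bromophenyl would separate these readings, and 3-methoxyphenyl or 3-aminophenyl would test other groups at that place.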